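This account rests on a few compounds, and the source may have more. Where it says the series, first, only, none or still open, it means among the compounds named here.

Measured so far:
- compound 1 `N#Cc1ccc(NC(=O)c2ccc(Br)cc2O)cc1Cl`: 440 nM
- compound 2 `N#Cc1ccc(NC(=O)c2ccc(-c3cccnc3)cc2O)cc1`: 6660 nM
- compound 3 `O=C(Nc1ccc(C(F)(F)F)cc1)c1ccc(Cl)cc1O`: 630 nM

In a functional assay on HL-60 cells (Homo sapiens) for cytotoxicity, read by luminescence and CellTiter-Glo, with a stated time of 3 days (a lower number here means a stronger inhibitor, a higher number a weaker inhibitor), compound 2 gives 6660 nM. This is the highest number of the three, so compound 2 is the weakest inhibitor here, and its gaps to both other compounds lie beyond the scatter.

Compound 4 `COc1ccc(C(=O)Nc2ccc(C#N)cc2)c(O)c1` has not been measured yet. It keeps the structure of compound 2 but carries methoxy in place of pyridin-3-yl on an aromatic carbon.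

Among the compounds with values here, no two measured compounds differ in one place only, so any guide is loose. Still, compound 1 at 440 nM and compound 3 at 630 nM carry a single halogen atom where compound 2 has its ring, and methoxy is also small. A lower number than for compound 2 is therefore expected, though probably not as low as these two.

The estimated step of a 4.4-fold lower number from compound 2 to compound 4 (0.65 log units; beyond the scatter) is a drop beyond the scatter. For compound 4 the expected value is 1500 nM, with an estimated range of 450 nM to 5000 nM.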

Compound 4, half-maximal inhibitory concentration: 5470 nM
Beside the measured number, compound 4's estimate is 3.6-fold (0.56 log units) below it, outside the stated range (above it).
By their numbers in this assay, from the lowest: compounds 1 and 3 (each within the scatter of the next); then compounds 4 and 2 (each within the scatter of the next).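

In this assay, putting methoxy in place of pyridin-3-yl, on the aromatic carbon para to a large group, gives a 1.2-fold lower number from compound 2 to compound 4 (0.09 log units; within the scatter), so this position accepts the loss of a whole aromatic ring, going from 6 heavy atoms to 2, with no change that can be told from the scatter. Compounds 1 and 3 differ from compound 2 in more than one place, so their values cannot be tied to this position alone. Nothing at hand explains why these two compounds give such close numbers.

Going by these compounds, what an amine or a carboxylic acid at this position would give remains open. So does whether a single halogen there, on the otherwise unchanged structure of compound 2, would move the number beyond the scatter.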